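The compounds below may be only part of what the source reports. "The series", "measured", "known", "first", "only" and "open" are said of these compounds alone.

In a functional assay on MGC-803 cells (Homo sapiens) for antiproliferative activity, read by MTT assay, with a stated time of 48 h (a higher number here means a weaker inhibitor, a lower number a stronger inhibitor), compound 1 `COc1ccc(CN(C(=O)Cn2cc(CSc3nnnn3C)nn2)c2cc(OC)c(OC)c(OC)c2)cc1` gives 6570 nM, while compound 2 `COc1ccc(CN(C(=O)Cn2cc(Cn3ccc4ccccc43)nn2)c2cc(OC)c(OC)c(OC)c2)cc1` gives 42600 nM, the higher of the two numbers. Compound 3 `COc1ccc(CN(C(=O)Cn2cc(CNS(=O)(=O)c3ccc(Br)cc3)nn2)c2cc(OC)c(OC)c(OC)c2)cc1` differs from compound 2 on the saturated chain carbon bound to an aromatic carbon, with ((4-bromophenyl)sulfonyl)amino in place of 1H-indol-1-yl on a saturated chain carbon bound to an aromatic carbon. For the measured compounds named here, one measured step bears on this position, a 6.5-fold higher number from compound 1 to compound 2 (0.81 log units; beyond the scatter), which is modest and shows 1H-indol-1-yl arriving at the higher number. A modest move to a lower number is therefore expected in this assay, estimated as a 3.6-fold lower number from compound 2 to compound 3 (0.55 log units; beyond the scatter). For compound 3 the estimated value is 12000 nM, within an expected range of 3000 nM to 45000 nM.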

Compound 3, half-maximal inhibitory concentration: 430 nM
For compound 3 the middle estimate is 28-fold (1.45 log units) above the measured one, and the stated range ends above it.
By their numbers in this assay, from the lowest: compound 3; then compound 1; then compound 2.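

In this assay, for the compounds shown here, the position on the saturated chain carbon bound to an aromatic carbon proves far more responsive than the single earlier step indicated. ((4-bromophenyl)sulfonyl)amino gives a 99-fold lower number from compound 2 to compound 3 (2.00 log units; beyond the scatter) and, against (1-methyl-1H-tetrazol-5-yl)sulfanyl, a 15-fold lower number from compound 1 to compound 3 (1.18 log units; beyond the scatter), so the change outruns both earlier groups. No measurement here accounts for this gain.

The compounds shown do not separate the contribution of the sulfonyl amino link from that of the bromine. A plain phenyl in place of 4-bromophenyl, or a carbonyl in place of the sulfonyl, would divide the two.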